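The compounds below may be only part of what the source reports. "The series", "measured", "known", "first", "only" and "open" are said of these compounds alone.

Compound 1, `O=C1[C@@H](NS(=O)(=O)c2cc3c(Cl)nccc3s2)CCN1CCNc1ccncc1`, gives 39% in an assay on isolated protein for inhibition of coagulation factor X (Oryctolagus cuniculus), tested at 1 uM; a lower number here means less inhibition, a higher number more inhibition at the concentration tested (going by the name of the read-out).
Compound 2, `Cc1c(S(=O)(=O)N[C@H]2CCN(Cc3cc4c[nH]ccc-4n3)C2=O)sc2ccc(Cl)cc12`, gives 37% in this assay.
Compound 3, `O=C1[C@@H](NS(=O)(=O)c2cc3c(Cl)nccc3s2)CCN1Cc1cc2c[nH]ccc-2n1`, gives 35% in this assay.

On these numbers compound 3 sits alongside compound 1 and compound 2: all three values lie within the usual scatter of one another, so none of them can be set apart from the others. Within the data shown here, the only step that joins two measured compounds in one place is a number 4 percentage points lower from compound 1 to compound 3 (within the scatter), and that change concerns the group on the saturated chain carbon bound to the ring amide nitrogen, far from the sulfonyl side of the molecule.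

Compound 4, `O=C1[C@@H](NS(=O)(=O)c2cc3ccc(Cl)nc3s2)CCN1Cc1cc2c[nH]ccc-2n1`, differs from compound 3 at that other end: a group of 10 heavy atoms (7 carbon, 1 nitrogen, 1 sulfur, 1 chlorine; one five-membered aromatic ring with 1 hetero atom, one six-membered aromatic ring with 1 hetero atom) in place of a group of 10 heavy atoms (7 carbon, 1 nitrogen, 1 sulfur, 1 chlorine; one five-membered aromatic ring with 1 hetero atom, one six-membered aromatic ring with 1 hetero atom), on a sulfonyl sulfur. Among the measured compounds shown here, no measured pair changes this part of the molecule, so there is no step that bears directly on it; the single measured step lies elsewhere and stayed within the scatter. The expectation is therefore that compound 4 behaves much like compound 3, with an expected step of a number 2 percentage points lower from compound 3 to compound 4 (within the scatter), nothing beyond the scatter in either direction. Compound 4 is estimated at 33%, with a range from 12% to 54%.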

Compound 4, a percentage reported as inhibition, at one concentration (the size of the read-out at that concentration, not a potency): 51%
Beside the measured number, compound 4's estimate is 18 percentage points below it; low and high end bracket the measured number.
By their numbers in this assay, from the lowest: compounds 3, 2 and 1 (each within the scatter of the next); then compound 4.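

Swapping one group on the sulfonyl sulfur for another built from the same atoms, joined differently, gives a number 16 percentage points higher from compound 3 to compound 4 (beyond the scatter) in this assay, so the way these atoms are connected matters here, even though the counts of heavy atoms, rings and hydrogen-bond acceptors stay identical. Among these compounds, this is the first change at the sulfonyl end that can be read, and it clears the scatter, whereas the one step at the other end of the molecule, a number 4 percentage points lower from compound 1 to compound 3 (within the scatter), does not. Nothing measured here explains why this rearrangement of atoms shifts the number.

Whether the same gain would appear with the group that compound 1 carries at the ring amide nitrogen remains an open question, since this result rests on a single pair of compounds. Also open, on these data alone, is what a bromine or a methoxy group in place of the chlorine would do on the sulfonyl-side group, and whether the difference at this one concentration would carry over to a full potency measurement.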